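A few compounds are considered here, and "the series" means these few. Any claim that something is new, unique, unknown or untested is made for them only; others in the source may bear on it.

- Compound 1 `CCCCCCCCCCCC[C@@H](O)[C@H]1CC[C@H]([C@H](O)CCCCCCCCCCNC(=O)c2ccnn2C)O1`: 18200 nM
- Compound 2 `CCCCCCCCCCCC[C@@H](O)[C@H]1CC[C@H]([C@H](O)CCCCCCCCCCNCc2ccnn2C)O1`: 2290 nM
- Compound 3 `CCCCCCCCCCCC[C@@H](O)[C@H]1CC[C@H]([C@H](O)CCCCCCCCCCC(=O)Nc2ccnn2C)O1`: 100000 nM

In a functional assay on PC-3 cells (Homo sapiens) for inhibition, read by sulforhodamine B assay, with a stated time of 48 h (on this read-out lower numbers stand for stronger inhibition of growth and higher numbers for weaker inhibition of growth), compound 3 has the highest number of the three, so it is the weakest growth inhibitor here. Compound 4 `CCCCCCCCCCCC[C@@H](O)[C@H]1CC[C@H]([C@H](O)CCCCCCCCCCOC(=O)c2ccnn2C)O1` differs from it by one swap: ((1-methyl-1H-pyrazol-5-yl)carbonyl)oxy in place of (1-methyl-1H-pyrazol-5-yl)carbamoyl on a saturated chain carbon, ten or more bonds along the chain from an oxygen on a saturated carbon and a saturated ring carbon. The entering ((1-methyl-1H-pyrazol-5-yl)carbonyl)oxy group resembles the group of compound 1, with oxy in place of amino, so the most relevant measured step is the modest 5.5-fold higher number from compound 1 to compound 3 (0.74 log units; beyond the scatter). The large 44-fold higher number from compound 2 to compound 3 (1.64 log units; beyond the scatter) shows that this end of the chain can matter, but compound 2 is a less close match. A modest move back towards compound 1 is therefore expected, and the expected step is a 4.0-fold lower number from compound 3 to compound 4 (0.60 log units; beyond the scatter). Compound 4 is estimated at 25000 nM, with an expected range of 8000 nM to 80000 nM.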

Compound 4, concentration for 50% growth inhibition: 28200 nM
The estimate for compound 4 lay 1.1-fold (0.05 log units) below the measured number; the measured number falls inside the stated range.
By their numbers in this assay, from the lowest: compound 2; then compounds 1 and 4 (each within the scatter of the next); then compound 3.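

In this assay, replacing the amino of compound 1 with oxy leaves the entering ((1-methyl-1H-pyrazol-5-yl)carbonyl)oxy group with no hydrogen-bond donor, yet the change stays within the scatter, a 1.5-fold higher number from compound 1 to compound 4 (0.19 log units; within the scatter), so the amide hydrogen is not needed to keep this level of growth inhibition. Link direction still counts, with a 3.5-fold lower number from compound 3 to compound 4 (0.55 log units; beyond the scatter), while the gap to the methylene-linked amine remains large, a 12-fold higher number from compound 2 to compound 4 (1.09 log units; beyond the scatter). No measurement here explains these differences.

Still open, as far as these compounds go, is how a plain ether link or a sulfonamide link would compare at this chain end. A shorter chain carrying the ((1-methyl-1H-pyrazol-5-yl)methyl)amino group of compound 2 also remains to be seen.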